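A few compounds are considered here, and "the series" means these few. Any claim that something is new, unique, unknown or untested is made for them only; others in the source may bear on it.

Compound 1 `CO[C@H]1CC[C@H](Nc2cc(NCc3cnccc3C(F)(F)F)ncc2C#N)CC1`: 1100 nM
Compound 2 `CO[C@H]1CC[C@@H](CNc2cc(NCc3cnccc3C(F)(F)F)ncc2C#N)CC1`: 70 nM
Compound 3 `N#Cc1cnc(NCc2cnccc2C(F)(F)F)cc1NCC1CCOCC1`: 400 nM

Of the compounds shown here, three sharing one core have been tested in an assay on isolated protein for inhibition of protein kinase C theta type (Homo sapiens), read by TR-FRET, with a stated time of 2 h; on this read-out higher numbers stand for weaker inhibition and lower numbers for stronger inhibition. Compound 3 gives 400 nM, the second highest of the three numbers: compound 1 is a weaker inhibitor, as shown by a 2.8-fold lower number from compound 1 to compound 3 (0.44 log units; beyond the scatter), while compound 2 is the strongest, as shown by a 5.7-fold higher number from compound 2 to compound 3 (0.76 log units; beyond the scatter). The largest step seen is a 16-fold lower number from compound 1 to compound 2 (1.20 log units; beyond the scatter), where a saturated chain carbon was inserted between the ring and the nitrogen on the aromatic ring.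

Compound 4 `CC1(C)[C@H](Nc2cc(NCc3cnccc3C(F)(F)F)ncc2C#N)C[C@H]1C(N)=O` has not yet been measured. Relative to compound 3 it carries 3-carbamoyl-2,2-dimethylcyclobutyl in place of (oxan-4-yl)methyl on a nitrogen on an aromatic ring. Two things change at once: the saturated chain carbon bound to the nitrogen on the aromatic ring is removed, so the ring is again attached as in compound 1, and the ring itself is replaced. The step of a 16-fold lower number from compound 1 to compound 2 (1.20 log units; beyond the scatter) speaks to the first change and points toward a higher number, while a 2.8-fold lower number from compound 1 to compound 3 (0.44 log units; beyond the scatter) and a 5.7-fold higher number from compound 2 to compound 3 (0.76 log units; beyond the scatter) show that exchanging the ring has shifted the number modestly in either direction. For the measured compounds named here, no measured compound carries a four-membered ring or a carbamoyl group, so that part is untested. Compound 4 is therefore expected to give a weaker value in this assay, estimated at 900 nM with a range from 200 nM to 4000 nM. This estimate corresponds to an expected step of a 2.3-fold higher number from compound 3 to compound 4 (0.35 log units; beyond the scatter).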

Compound 4, half-maximal inhibitory concentration: 140 nM
For compound 4 the middle estimate is 6.4-fold (0.81 log units) above the measured one, and the stated range ends above it.
By their numbers in this assay, from the lowest: compounds 2 and 4 (each within the scatter of the next); then compound 3; then compound 1.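

In this assay, a ring attached directly to the nitrogen on the aromatic ring, with no saturated chain carbon, does not have to give a weak number: placing 3-carbamoyl-2,2-dimethylcyclobutyl there instead of 4-methoxycyclohexyl gives (a 7.9-fold lower number from compound 1 to compound 4 (0.90 log units; beyond the scatter)), so the weak value of compound 1 is not shared by every such ring. The same group also improves on (oxan-4-yl)methyl (a 2.9-fold lower number from compound 3 to compound 4 (0.46 log units; beyond the scatter)), while the comparison with (4-methoxycyclohexyl)methyl (a 2.0-fold higher number from compound 2 to compound 4 (0.30 log units; within the scatter)) stays within the scatter, so the two groups cannot be told apart here even though only the latter has the saturated chain carbon. Nothing available explains why this group is tolerated so well at this position.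

The compounds shown do not separate what the four-membered ring, the two methyl groups and the carbamoyl group each contribute, which a plain cyclobutyl, a 3-carbamoylcyclobutyl or a version carrying a carboxylic acid in place of the carbamoyl group could help to sort out. They also leave open how the other stereoisomers of the cyclobutyl group behave, and whether a (3-carbamoyl-2,2-dimethylcyclobutyl)methyl group would give a further gain.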